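Hydroxy at the benzhydryl carbon of compound 2

This account rests on a few compounds, and the source may have more. Where it says the series, first, only, none or still open, it means among the compounds named here.

Two compounds of this series carry numbers. In a functional assay (plasma) with Oryctolagus cuniculus as the target (a higher number here means a weaker inhibitor, a lower number a stronger inhibitor), compound 1 `Cc1nc2cnccc2n1C1CCN(C(=O)CC(c2ccccc2)c2ccccc2)CC1` gives 100 nM, and in this assay compound 2 `Cc1nc2cnccc2n1CC1CCN(C(=O)CC(c2ccccc2)c2ccccc2)CC1` gives 7.6 nM. Going by the values given here, compound 2 stands lowest of the two numbers, and its only neighbour is compound 1, separated by a 13-fold lower number from compound 1 to compound 2 (1.12 log units; beyond the scatter), a change at the saturated ring carbon that carries the bicyclic group.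

Compound 3 `Cc1nc2cnccc2n1CC1CCN(C(=O)CC(O)(c2ccccc2)c2ccccc2)CC1` differs from compound 2 at a different place: hydroxy in place of hydrogen on a saturated chain carbon bound to two aromatic carbons and a saturated chain carbon. Among the compounds with values here, the single measured step concerns the group on the piperidine ring and not the carbon that bears the two phenyl rings, so no measured step bears on this change, and the series offers no direct precedent for it. In this assay the number for compound 3 is therefore expected to stay close to that of compound 2, with a step of a 1.3-fold lower number from compound 2 to compound 3 (0.10 log units; within the scatter) that need not exceed the scatter. The estimate for compound 3 in this assay is 6 nM, with a range from 1.5 nM to 25 nM.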

Compound 3, half-maximal inhibitory concentration: 640 nM
Beside the measured number, compound 3's estimate is 110-fold (2.03 log units) below it; measured number above the stated range.
By their numbers in this assay, from the lowest: compound 2; then compound 1; then compound 3.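

In this assay, the saturated chain carbon bound to two aromatic carbons and a saturated chain carbon proves sensitive to substitution: hydroxy in place of hydrogen there gives an 84-fold higher number from compound 2 to compound 3 (1.93 log units; beyond the scatter) and takes the series toward weaker inhibition. Going by these compounds alone, this one heavy atom moves the number further than the exchange of groups on the saturated ring carbon did (a 13-fold lower number from compound 1 to compound 2 (1.12 log units; beyond the scatter)), so the chain carbon, which the earlier compounds left unchanged, now counts as a second position with a large effect on this read-out. No measurement at hand accounts for the size of this loss, and its origin stays unexplained.

The compounds shown leave open whether the loss is specific to hydroxy or follows from any group on this carbon, a question that fluoro, methyl, methoxy or an amine at the same place would help to settle. Also open, as far as these compounds go, is whether hydroxy at this carbon costs as much when the saturated ring carbon carries the group of compound 1 instead of that of compound 2.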